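The source may hold more compounds than are shown below. What is called first, only, known or untested is meant among the compounds shown, and "the series" means these compounds.

Going by the values given here, in an assay on microsomes for inhibition of acyl-CoA:cholesterol acyltransferase (Oryctolagus cuniculus) (on this read-out lower numbers stand for stronger inhibition and higher numbers for weaker inhibition), compound 3 `CC(C)c1cccc(C(C)C)c1NC(=O)NCC1(c2ccc(F)cc2)CCCC1` gives 23 nM, the lowest of the three numbers measured so far. Compound 1 `CC(C)c1ccc(C2(CNC(=O)Nc3c(C(C)C)cccc3C(C)C)CCCC2)cc1` gives 48 nM and compound 2 `CC(C)c1cccc(C(C)C)c1NC(=O)NCC1(c2ccc(C(C)(C)C)cc2)CCCC1` gives 63 nM. The steps of a 2.1-fold lower number from compound 1 to compound 3 (0.32 log units; beyond the scatter) and a 2.7-fold lower number from compound 2 to compound 3 (0.44 log units; beyond the scatter) both show a modest fall when fluoro stands in place of a large group on that aromatic carbon, whereas a 1.3-fold higher number from compound 1 to compound 2 (0.12 log units; within the scatter) lies within the scatter. Compound 4 `CC(C)c1cccc(C(C)C)c1NC(=O)NCC1(c2ccc(OCc3ccccc3)cc2)CCCC1` differs from compound 3 by benzyloxy in place of fluoro on an aromatic carbon. For compound 4 a modest rise a 2.6-fold higher number from compound 3 to compound 4 (0.42 log units; beyond the scatter) is expected in this assay, because compound 1 gave 48 nM and compound 2 gave 63 nM with a large group on the same carbon. Compound 4 is therefore estimated at 60 nM, with a range from 25 nM to 150 nM.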

Compound 4, half-maximal inhibitory concentration: 34 nM
Compound 4: the middle estimate sits 1.8-fold (0.25 log units) above what was measured; measured number inside the range.
By their numbers in this assay, from the lowest: compounds 3, 4, 1 and 2 (each within the scatter of the next, the first and the last beyond it).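

In this assay, benzyloxy, a group carrying its own aromatic ring, is accepted on this aromatic carbon: a 1.5-fold higher number from compound 3 to compound 4 (0.17 log units; within the scatter), a 1.4-fold lower number from compound 1 to compound 4 (0.15 log units; within the scatter) and a 1.9-fold lower number from compound 2 to compound 4 (0.27 log units; within the scatter) all stay within the scatter. Group size alone therefore does not order this position, since compound 4 has the largest group here yet cannot be separated from compound 1, compound 2 or compound 3. Nothing available here bears on the reason for this. Going by these compounds, whether an amine, a carboxylic acid or a longer chain such as phenethyloxy on this carbon stays in the same range remains open.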